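This account rests on a few compounds, and the source may have more. Where it says the series, first, only, none or still open, it means among the compounds named here.

Compound 1 `Fc1ccc(-c2[nH]c3cc(Cl)ccc3c2Cn2ccnc2)cc1` in an ADME assay on MCF7 cells (Homo sapiens) for cytotoxicity, read by MTT assay, with a stated time of 48 h (on this read-out lower numbers stand for stronger inhibition and higher numbers for weaker inhibition), gives 41500 nM. Compound 2 `Clc1ccc(-c2[nH]c3cc(Cl)ccc3c2Cn2ccnc2)cc1` gives in this assay only a limit, > 1000000 nM. Compound 3 `COc1ccc2c(Cn3ccnc3)c(-c3ccc(Cl)cc3)[nH]c2c1` likewise gives only a limit in this assay, > 1000000 nM.

Compound 2 thus stands at the limit of > 1000000 nM in this assay, at which 2 of the 3 values shown sit; its number is a limit of the assay and not a measured value. Compound 4 `Clc1ccc(-c2[nH]c3cc(Cl)ccc3c2Cn2cncn2)cc1` differs from compound 2 by 1H-1,2,4-triazol-1-yl in place of 1H-imidazol-1-yl on a saturated chain carbon bound to an aromatic carbon. Of the measured steps, an at least 24-fold higher number from compound 1 to compound 2 (1.38 log units; beyond the scatter) and a step that the two limits leave unreadable from compound 2 to compound 3 both alter a substituent on an aromatic carbon, and neither touches the 1H-imidazol-1-yl group, so none bears on the step to compound 4. Compound 4 is therefore expected to stay near where compound 2 sits, the step of a number no higher from compound 2 to compound 4 (the limit leaves the size open) being estimated as none beyond the scatter. Compound 4 is expected at 1000000 nM, within 200000 nM to 5000000 nM.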

Compound 4, half-maximal inhibitory concentration: 382000 nM
Estimate against measurement, compound 4: 2.6-fold (0.42 log units) above, within the range that was stated.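

In this assay there is an at least 2.6-fold lower number from compound 2 to compound 4 (0.41 log units; beyond the scatter) when 1H-1,2,4-triazol-1-yl takes the place of 1H-imidazol-1-yl on a saturated chain carbon bound to an aromatic carbon. For the compounds shown here, this position, which the earlier steps left untouched, therefore also moves the read-out. As far as these compounds go, the full size of the step stays open, because compound 2 holds only a limit: the limit of > 1000000 nM in this assay, at which 2 of the 4 values shown sit.

From the compounds shown here alone, whether this exchange acts the same way with the fluoro group of compound 1 or the methoxy group of compound 3 remains open. Also open, going by these compounds, is how an amine or a carboxylic acid would read at this position.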